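A few compounds are considered here, and "the series" means these few. Any claim that something is new, unique, unknown or untested is made for them only; others in the source may bear on it.

Values in a functional assay on microsomes for inhibition, with a stated time of 1 h; on this read-out higher numbers stand for weaker inhibition and lower numbers for stronger inhibition:

compound 1 `CCOC(=O)c1cnn(-c2nc(-c3ccccc3F)c(C#N)c(=O)n2C)c1N` — 94 ug/mL
compound 2 `CCOC(=O)c1cnn(-c2nc(-c3ccccc3Cl)c(C#N)c(=O)n2C)c1N` — 102 ug/mL
compound 3 `Cn1c(NN)nc(-c2ccccc2Cl)c(C#N)c1=O` — 57 ug/mL

Compound 2 and compound 1 share one core and differ only by fluoro in place of chloro on an aromatic carbon. In this assay this gives a 1.1-fold lower number from compound 2 to compound 1 (0.04 log units; within the scatter), so the two compounds are not separated by this assay. Compound 3 is built on a different core; the difference between the core of compound 3 and the core of compound 2 is not broken down here. Compound 3 returns the lowest of the three numbers, yet its gaps to compound 1 and to compound 2 both lie within the scatter, so no order among the three is claimed.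

Compound 4 `Cn1c(NN)nc(-c2ccccc2F)c(C#N)c1=O` is not yet measured. It differs from compound 3 by fluoro in place of chloro on an aromatic carbon, and the place is described in the same words as for the change from compound 2 to compound 1, so the two changes count as the same change, made on two different cores. For the measured compounds named here, only one measured instance of this change exists, which leaves the expectation weakly founded. Compound 4 is expected to move from compound 3 by a 1.1-fold lower number from compound 3 to compound 4 (0.03 log units; within the scatter) in this assay, a step chosen to sit close to the observed one because a 1.1-fold lower number from compound 2 to compound 1 (0.04 log units; within the scatter) stayed within the scatter. Compound 4 is therefore estimated at 53 ug/mL in this assay, with a range of 28 ug/mL to 100 ug/mL allowing for the scatter and for the change of core.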

Compound 4, half-maximal inhibitory concentration: 43 ug/mL
Estimate against measurement, compound 4: 1.2-fold (0.09 log units) above, and the stated range covers the measured number.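

Fluoro in place of chloro on an aromatic carbon, ortho to a large group, now stands on two cores in this assay, and on the second core it gives a 1.3-fold lower number from compound 3 to compound 4 (0.12 log units; within the scatter). Set side by side, the two steps do not differ: the same change on two cores in this assay, a 1.1-fold lower number (0.04 log units; within the scatter) from compound 2 to compound 1 and a 1.3-fold lower number (0.12 log units; within the scatter) from compound 3 to compound 4, 1.2-fold (0.09 log units) apart, within the scatter of two such steps

Within these four compounds, the change therefore carries from one core to the other without a step that can be told from the scatter, on either core; it does not show a true shift in either direction, nor that the two cores respond alike in any finer sense, and two pairs give no basis for extending this to further cores or to other read-outs.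

The compounds shown leave open whether anything other than a halogen on that aromatic carbon, such as a methoxy group or an amine, would give a step beyond the scatter. Also open, going by these compounds, is how far the number in this assay would move with a carboxylic acid in place of the nitrile, or with a longer chain in place of the methyl on the ring nitrogen, on either core.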